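A few compounds are considered here, and "the series" means these few. Any claim that something is new, unique, unknown or untested is made for them only; others in the source may bear on it.

Measured in a functional assay on MCF7 cells (Homo sapiens) for cytotoxicity, read by MTT assay, with a stated time of 96 h; on this read-out higher numbers stand for weaker inhibition and lower numbers for stronger inhibition:
- Compound 1 `COc1cc(C(=O)c2cn(-c3cccc(C)c3)cc2-c2ccc(N)cc2)cc(OC)c1OC`: 18 nM
- Compound 2 `COc1cc(C(=O)c2cn(-c3ccc(C)cc3)cc2-c2cccc(N)c2)cc(OC)c1OC`: 53 nM

Of these two numbers, compound 2 at 53 nM is the higher one, so it inhibits more weakly than compound 1, and the gap lies beyond the scatter of repeat measurements.

The next compound to be tested is compound 3 `COc1cc(C(=O)c2cn(-c3ccc(C)cc3)cc2-c2ccc(N)cc2)cc(OC)c1OC`. It has 4-aminophenyl in place of the 3-aminophenyl of compound 2, on an aromatic carbon of the five-membered ring: 4-aminophenyl in place of 3-aminophenyl on an aromatic carbon. Among the measured compounds shown here, no measured pair shows this change alone, so the forecast is uncertain. It rests on compound 1, which also carries 4-aminophenyl and gives 18 nM. Stronger inhibition in this assay is therefore expected, as a moderate move: the expected change is a 2.4-fold lower number from compound 2 to compound 3 (0.38 log units; beyond the scatter). For compound 3 the estimated value is 22 nM, with an expected range of 7 nM to 70 nM.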

Compound 3, half-maximal inhibitory concentration: 6 nM
Compound 3: middle estimate off by 3.7-fold (0.56 log units), on the high side; the measured number lies below the stated range.
By their numbers in this assay, from the lowest: compound 3; then compound 1; then compound 2.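

In this assay, the aminophenyl group on the aromatic carbon of the five-membered ring can now be read alone: 4-aminophenyl in place of 3-aminophenyl gives an 8.8-fold lower number from compound 2 to compound 3 (0.95 log units; beyond the scatter) and so the position of the amine on that group matters in this series. The group on the ring nitrogen also responds to a shift of a single substituent, since 4-methylphenyl in place of 3-methylphenyl gives a 3.0-fold lower number from compound 1 to compound 3 (0.48 log units; beyond the scatter) and this step runs in the same direction as the first. Nothing available explains why either shift changes the number.

Still open is whether the amine itself is needed, as every compound shown carries one, so a hydroxyl or a methoxy group in its place would test this. Likewise open, going by these compounds, is whether an ethyl group or a chlorine atom could stand in for the methyl group.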